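A few compounds are considered here, and "the series" means these few. Any claim that something is new, unique, unknown or untested is made for them only; others in the source may bear on it.

Measured in a functional assay for inhibition, with Homo sapiens as the target; on this read-out lower numbers stand for stronger inhibition and higher numbers for weaker inhibition:
compound 1 `OC1(c2cccc(COc3ccc4c(-c5ccoc5)cc(C5=NCCO5)cc4c3)c2)CCOCC1`: 3 nM
compound 2 `CC1(C)COC(c2cc(-c3ccoc3)c3ccc(OCc4cccc(C5(O)CCOCC5)c4)cc3c2)=N1`: 17 nM
compound 3 `OC1(c2cccc(COc3ccc4c(-c5ccoc5)cc(-c5nc6ccccc6s5)cc4c3)c2)CCOCC1`: > 62 nM

Compound 3 has no exact number and stands at the limit of > 62 nM in this assay, at which 1 of the 3 values shown sits, which is a limit of the read-out. Compound 4 `OC1(c2cccc(COc3ccc4c(-c5ccoc5)cc(Cc5nccs5)cc4c3)c2)CCOCC1` carries (1,3-thiazol-2-yl)methyl in place of 1,3-benzothiazol-2-yl on an aromatic carbon.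

Among the compounds with values here, three measured steps concern this same place. They are a 5.7-fold higher number from compound 1 to compound 2 (0.75 log units; beyond the scatter), an at least 20-fold higher number from compound 1 to compound 3 (1.31 log units; beyond the scatter) and an at least 3.6-fold higher number from compound 2 to compound 3 (0.56 log units; beyond the scatter). Among these three compounds the number in this assay rises as the group grows, and none of them goes against this. Compound 4 loses the fused six-membered ring of the leaving group, so a step toward a lower number, meaning stronger inhibition, is expected. Within the data shown here, no measured compound has a group of the entering kind, so the size of the step remains uncertain. The expected change is an at least 2.4-fold lower number from compound 3 to compound 4 (0.39 log units; beyond the scatter). For compound 4 the estimated value is 25 nM, with an expected range of 6 nM to 100 nM.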

Compound 4, half-maximal inhibitory concentration: 1 nM
Beside the measured number, compound 4's estimate is 25-fold (1.40 log units) above it; measured number outside the range, below it.
By their numbers in this assay, from the lowest: compound 4; then compound 1; then compound 2. At a limit, above all of these: compound 3.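

Compound 3 gives only a limit of the read-out in this assay: the limit of > 62 nM in this assay, at which 1 of the 4 values shown sits.

Read against that limit, (1,3-thiazol-2-yl)methyl gives an at least 62-fold lower number from compound 3 to compound 4 (1.79 log units; beyond the scatter), and against the dimethylated ring of compound 2 it gives a 17-fold lower number from compound 2 to compound 4 (1.23 log units; beyond the scatter), so this position accepts an aromatic five-membered ring carried on a methyl link. Group size alone no longer orders the series: the group of compound 4 is larger than that of compound 1, yet there is a 3.0-fold lower number from compound 1 to compound 4 (0.48 log units; beyond the scatter), and compound 4 goes against the earlier rise of the number with size.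

Open, going by these compounds, is whether the lower number follows from the methyl link or from the loss of the fused six-membered ring, which directly attached 1,3-thiazol-2-yl would separate. Also open, on these data alone, is how far the link tolerates change, for example an ethyl link to the same thiazole or benzyl in its place.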